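Ortho versus para methoxyphenyl on a thiazolyl-triazolethione series

The compounds below may be only part of what the source reports. "The series", "measured", "known", "first", "only" and "open" are said of these compounds alone.

Measured compounds:
compound 1 `COc1ccc(-n2c(Nc3nc(-c4ccc([N+](=O)[O-])cc4)cs3)n[nH]c2=S)cc1`: 100 mg/kg
compound 2 `COc1ccccc1-n1c(Nc2nc(-c3ccc([N+](=O)[O-])cc3)cs2)n[nH]c1=S`: 100 mg/kg
compound 3 `COc1ccc(-n2c(Nc3nc(-c4ccc(Cl)cc4)cs3)n[nH]c2=S)cc1`: 30 mg/kg

The three measured compounds were examined in a functional assay on the whole organism (strain Swiss albino) for inhibition, with Mus musculus as the target, with a stated time of 0.5 h; on this read-out lower numbers stand for an effect already at smaller amounts and higher numbers for an effect only at larger amounts of compound. Compound 1 gives 100 mg/kg in this assay, and compound 2 gives 100 mg/kg. The two differ only in 2-methoxyphenyl in place of 4-methoxyphenyl on an aromatic nitrogen; this change made no change at the digits printed from compound 1 to compound 2 (within the scatter). Compound 3 differs from compound 1 in chloro in place of nitro on an aromatic carbon; compound 3 gives 30 mg/kg, the step being a 3.3-fold lower number from compound 1 to compound 3 (0.52 log units; beyond the scatter). Compound 3 thus stands at the lowest number of the three, and its steps to compound 1 and to compound 2 are both beyond the scatter.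

Compound 4 `COc1ccccc1-n1c(Nc2nc(-c3ccc(Cl)cc3)cs2)n[nH]c1=S` has not yet been measured in this assay. It differs from compound 3 in 2-methoxyphenyl in place of 4-methoxyphenyl on an aromatic nitrogen. This is the same change as the one from compound 1 to compound 2, made twice among these compounds, and the place around it is described in the same words in both pairs. The two cores on which the change is made differ in chloro in place of nitro on an aromatic carbon.

The expectation for compound 4 rests on the earlier pair: the step for compound 4 is expected to be about no change at the digits printed from compound 3 to compound 4 (within the scatter), as the same change gave no change at the digits printed from compound 1 to compound 2 (within the scatter). Compound 4 is therefore estimated at 30 mg/kg in this assay, with a likely range from 15 mg/kg to 60 mg/kg.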

Compound 4, minimum effective dose: 100 mg/kg
Estimate against measurement, compound 4: 3.3-fold (0.52 log units) below, and the stated range ends below it.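

On the core of compound 3, the swap of 4-methoxyphenyl for 2-methoxyphenyl gave a 3.3-fold higher number from compound 3 to compound 4 (0.52 log units; beyond the scatter), so the result seen on the core of compound 1 did not carry over, and the two steps differ when set side by side: the same change on two cores in this assay, no change at the digits printed (within the scatter) from compound 1 to compound 2 and a 3.3-fold higher number (0.52 log units; beyond the scatter) from compound 3 to compound 4, 3.3-fold (0.52 log units) apart, beyond the scatter of two such steps

Read the other way, chloro in place of nitro gave no change at the digits printed from compound 2 to compound 4 (within the scatter) on the 2-methoxyphenyl compounds, and this too differs from the step on the 4-methoxyphenyl compounds: the same change on two cores in this assay, a 3.3-fold lower number (0.52 log units; beyond the scatter) from compound 1 to compound 3 and no change at the digits printed (within the scatter) from compound 2 to compound 4, 3.3-fold (0.52 log units) apart, beyond the scatter of two such steps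

Within these four compounds, the two changes therefore cannot be treated as independent, and in this assay only compound 3 stands apart from the other three, but this is a single set of four compounds and it gives neither a general rule for the series nor a reason for the difference.

The compounds shown leave open whether a fluoro, a methyl or a carboxylic acid in the place of chloro would behave like chloro or like nitro on either methoxyphenyl compound. From the compounds shown here alone, it also remains open whether an ethoxy or a longer chain in the place of methoxy would keep the lower number of compound 3 or lose it.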